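The compounds below may be only part of what the source reports. "The series", "measured", "known", "first", "only" and "open" are said of these compounds alone.

Compound 1 `COCCOc1cc2oc(=O)n(CCC(=O)O)c2cc1Cl` is the most polar of the three measured compounds: in a physicochemical assay for lipophilicity, read by HPLC, at pH 7.4 (a lower number here means a more polar compound, a higher number a more lipophilic compound), compound 1 gives 0.88, while compound 2 `C[C@@H](Oc1cc2onc(CCC(=O)O)c2cc1Cl)c1ccc(F)cn1` gives 2.47 and compound 3 `C[C@@H](Oc1cc2onc(CCC(=O)O)c2cc1Cl)c1ccccn1` gives 1.99. Among the measured compounds shown here, the only single-point step measured, a number 0.48 log units lower from compound 2 to compound 3 (beyond the scatter), shows that one change on an aromatic ring can move the result noticeably. Compound 4 `C[C@@H](Oc1cc2oc(=O)n(CCC(=O)O)c2cc1Cl)c1ncccn1` differs from compound 1 by a group of 8 heavy atoms (6 carbon, 2 nitrogen; one six-membered aromatic ring with 2 hetero atoms) in place of a group of 4 heavy atoms (3 carbon, 1 oxygen; no ring), on an oxygen on an aromatic ring. For the measured compounds named here, no measured step mirrors this change, and the shared core of compounds 2 and 3 is not that of compound 1, so the comparison is indirect. The larger entering group, which carries an aromatic ring, is expected to give a step of a number 0.62 log units higher from compound 1 to compound 4 (beyond the scatter), and compound 4 is estimated at 1.5, within 0.9 to 2.1.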

Compound 4, distribution coefficient: 0.83
Compound 4: the middle estimate sits 0.67 log units above what was measured; measured number below the stated range.
By their numbers in this assay, from the lowest: compounds 4 and 1 (each within the scatter of the next); then compound 3; then compound 2.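

In this assay, a group of 8 heavy atoms carrying a six-membered aromatic ring, in place of 2-methoxyethyl, gives a number 0.05 log units lower from compound 1 to compound 4 (within the scatter) on this oxygen on an aromatic ring. On the core of compound 1, then, a larger entering group with an aromatic ring need not move the number. Nothing available explains this result.

From the compounds shown here alone, it remains open whether a plain phenyl ring or a longer chain ending in an amine on the same oxygen would also leave the number in place. Going by these compounds, the same swap on the core of compound 2 and compound 3 also remains open.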